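The compounds below may be only part of what the source reports. "The series", "measured", "known", "first", "only" and "open" are said of these compounds alone.

Compound 1 `CN1CCN(c2nc(Cl)nc3c2ncn3Cc2ccc(C(=O)Nc3ccccc3N)cc2)CC1` and compound 2 `CC(C)n1cnc2c(NCc3ccc(C(=O)Nc4ccccc4N)cc3)nc(Cl)nc21` share a core that carries a benzamide bearing an aminophenyl group, and both were tested in a functional assay on HeLa cells (Homo sapiens) for antiproliferative activity, read by CCK-8 assay, with a stated time of 72 h; on this read-out higher numbers stand for weaker inhibition and lower numbers for stronger inhibition. In this assay compound 1 gives 1170 nM, while compound 2 gives 2130 nM; compound 1 has the lowest of the two numbers, but the gap to compound 2 lies within the scatter, so no order between them can be claimed. Compound 3 `Nc1ccccc1NC(=O)c1ccc(Cn2cnc3c(Nc4cccc(Cl)c4)nc(Cl)nc32)cc1` is built from compound 1 by a single exchange: (3-chlorophenyl)amino in place of 4-methylpiperazin-1-yl on an aromatic carbon. Among the measured compounds shown here, no step between measured compounds covers an exchange of this kind, so the expectation rests on compound 1 alone. Compound 3 is expected to come out close to compound 1, with a step of a 1.5-fold lower number from compound 1 to compound 3 (0.17 log units; within the scatter) that stays within the scatter, leaning if anything toward the stronger side. Compound 3 is therefore estimated at 800 nM in this assay, with a range from 200 nM to 3200 nM.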

Compound 3, half-maximal inhibitory concentration: 11300 nM
For compound 3 the middle estimate is 14-fold (1.15 log units) below the measured one; measured number outside the range, above it.
By their numbers in this assay, from the lowest: compounds 1 and 2 (each within the scatter of the next); then compound 3.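

In this assay, placing (3-chlorophenyl)amino instead of 4-methylpiperazin-1-yl on this aromatic carbon gives a 9.7-fold higher number from compound 1 to compound 3 (0.98 log units; beyond the scatter) and moves the result toward weaker inhibition beyond the scatter. Among the compounds shown here, this is the first readable step at this position, and it shows that the position is not indifferent to the group it carries. No measured evidence here accounts for the change, and the step alone cannot separate the loss of the non-aromatic ring from the arrival of the aromatic ring, the chloro group or the hydrogen-bond donor.

The compounds shown leave open which of these differences carries the step. They also leave open how groups such as morpholin-4-yl or phenylamino without the chloro group would read at this aromatic carbon.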